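A Methyl Added Along the Chain

A few compounds are considered here, and "the series" means these few. Any claim that something is new, unique, unknown or untested is made for them only; others in the source may bear on it.

In a functional assay on the whole organism for antagonist activity, with Mus musculus as the target (on this read-out higher numbers stand for an effect only at larger amounts of compound and lower numbers for an effect already at smaller amounts), compound 1 `COC(=O)N(C)CC#CCn1cncc1C` gives 3 mg/kg. Compound 3 `CCOC(=O)N(C)CC#CCn1cncc1C` differs from it by methyl in place of hydrogen on a saturated chain carbon bound to an oxygen next to a carbonyl group, and in this assay compound 3 gives 66 mg/kg, so the step of a 22-fold higher number from compound 1 to compound 3 (1.34 log units; beyond the scatter). Compound 2 `CCOC(=O)N(C)CC#CCN1CCCC1` carries the same chain on a different core; how the two cores differ is not broken down here. For compound 2 this assay reports only a limit, > 100 mg/kg. Compound 4 `CCOC(=O)N(C)C(C)C#CCN1CCCC1` differs from compound 2 by methyl in place of hydrogen on a saturated chain carbon bound to an amide-type nitrogen and a triple-bonded carbon. This is the same kind of change as before, but here the methyl sits on a saturated chain carbon bound to an amide-type nitrogen and a triple-bonded carbon, not on a saturated chain carbon bound to an oxygen next to a carbonyl group. Compound 4 is expected to give 300 mg/kg because the earlier change a 22-fold higher number from compound 1 to compound 3 (1.34 log units; beyond the scatter) raised the number. The expected step is a step that the limit leaves unreadable from compound 2 to compound 4, most likely again ending at a limit.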

Compound 4, dose for half-maximal effect: 97 mg/kg
For compound 4 the middle estimate is 3.1-fold (0.49 log units) above the measured one, and the stated range ends above it.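

Compound 2 is known only through a limit, and in this assay an at least 1.0-fold lower number from compound 2 to compound 4 (0.01 log units; that floor lies within the scatter) is a floor, not a full size. Even so, the methyl does not carry over from one core to the other with the same result: the same change on two cores in this assay, a 22-fold higher number (1.34 log units; beyond the scatter) from compound 1 to compound 3 and an at least 1.0-fold lower number (0.01 log units; that floor lies within the scatter) from compound 2 to compound 4, at least 22-fold (1.35 log units) apart, beyond the scatter of two such steps This does not isolate the core's role, as one methyl sits on a saturated chain carbon bound to an oxygen next to a carbonyl group and the other on a saturated chain carbon bound to an amide-type nitrogen and a triple-bonded carbon.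

Open, on these data alone, is how each methyl would act at its own place on the other core. Also open, as far as these compounds go, is what a fluorine atom would do in place of either methyl.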